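This account rests on a few compounds, and the source may have more. Where it says the series, first, only, none or still open, it means among the compounds named here.

In a physicochemical assay for solubility, read by HPLC, using the shake flask method, in phosphate buffer, measured as kinetic solubility, with a stated time of 20 h, at pH 6.5 (on this read-out higher numbers stand for higher solubility and lower numbers for lower solubility), compound 1 `Fc1ccc(Nc2cc3[nH]c(Nc4ccc(N5CCNCC5)cn4)nc3cn2)cc1C(F)(F)F` gives 180000 nM, and compound 2 `Fc1ccc(Nc2cc3[nH]c(Nc4cc(N5CCNCC5)ccn4)nc3cn2)cc1C(F)(F)F` gives 95000 nM. These two numbers lie within the usual scatter of repeated measurements, so they cannot be ranked. Together they mark a single starting level, and compound 1 stands on that level.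

A further molecule, compound 3 `Fc1ccc(Nc2cc3[nH]c(Nc4ccc(N5CCN(CC6CC6)CC5)cn4)nc3cn2)cc1C(F)(F)F`, has not yet been measured. It is compound 1 with cyclopropylmethyl in place of hydrogen on an amine nitrogen in a ring, so that piperazin-1-yl becomes 4-(cyclopropylmethyl)piperazin-1-yl (cyclopropylmethyl in place of hydrogen on an amine nitrogen in a ring). The rest of the molecule stays the same, which makes this a clean single change to follow.

Going by the values given here, no measured pair here shows what this replacement does in this assay. Any forecast therefore rests only on the structural change and on the starting value of compound 1, 180000 nM. A moderate fall is expected, somewhat beyond the usual scatter, and the estimated step runs a 3.0-fold lower number from compound 1 to compound 3 (0.48 log units; beyond the scatter). Compound 3 is expected to read about 60000 nM, with an estimated range from 20000 nM to 150000 nM.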

Compound 3, solubility: 75000 nM
Compound 3: middle estimate off by 1.3-fold (0.10 log units), on the low side, and the stated range covers the measured number.
By their numbers in this assay, from the lowest: compounds 3, 2 and 1 (each within the scatter of the next, the first and the last beyond it).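

Going by these compounds alone, this is the first reading of what a group on this amine nitrogen does. In this assay, cyclopropylmethyl in place of hydrogen, three ring bonds from the ring nitrogen, gives a 2.4-fold lower number from compound 1 to compound 3 (0.38 log units; beyond the scatter) as a modest step that lies beyond the usual scatter, so this change moves the read-out by a measurable amount, though not by a large one. The number falls without collapsing, since compound 3 still gives 75000 nM in this assay, but nothing measured here bears on why the number falls.

This is also a single pair, so it shows the effect of one group in one setting and cannot yet be read as a rule for this position. A smaller group such as methyl, a longer chain such as n-butyl, or a chain ending in a hydroxyl or a carboxylic acid on the same nitrogen would show whether the step follows the size of the group or depends on its atoms, and cyclopropylmethyl on the piperazin-1-yl of compound 2 would show whether the step carries over to that close relative.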